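The source may report more compounds than this note shows. Statements on the series, on what has been measured and on what is new or still open speak of the compounds shown alone.

Compound 1 `Cc1c(C=O)cc(-c2ccc(S(C)(=O)=O)cc2)n1-c1ccccc1`: 23%
Compound 2 `Cc1c(/C=N\O)cc(-c2ccc(S(C)(=O)=O)cc2)n1-c1ccc(F)cc1`: 36%
Compound 3 `Cc1c(/C=N\O)cc(-c2ccc(S(C)(=O)=O)cc2)n1-c1cccc(F)c1`: 32%

In a functional assay on the whole organism (strain Swiss albino) for inhibition, with Mus musculus as the target, in the writhing test, with a stated time of 30 min, at a dose of 10 mg/kg by the oral route (on this read-out higher numbers stand for a stronger effect at the one dose given and lower numbers for a weaker effect), compound 3 gives 32%, the second highest of the three numbers. Its nearest neighbour is compound 2, and the step of a number 4 percentage points lower from compound 2 to compound 3 (within the scatter) lies within the scatter. Compound 1, the furthest of the three, shows a lower number, but the two values lie within the scatter of each other and no single change connects them.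

Compound 4 `Cc1c(/C=N\O)cc(-c2ccc(S(C)(=O)=O)cc2)n1-c1ccccc1` is reached from compound 3 by hydrogen in place of fluoro on an aromatic carbon. Among the measured compounds shown here, the only measured step that touches the fluorine on this ring is the one from compound 2 to compound 3, where moving the fluoro from one place on the ring to another changed the read-out by an amount within the scatter. For the measured compounds named here, no measured step removes the fluoro outright; compound 1 lacks it but also carries a different group elsewhere. On this basis compound 4 is expected to sit close to compound 3, with a step of a number 2 percentage points lower from compound 3 to compound 4 (within the scatter) that stays within the scatter. The estimate for compound 4 in this assay is therefore 30%, ranging from 18% to 42%.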

Compound 4, a percentage reported as inhibition, in the whole organism at one dose (the size of the read-out at that dose, not a potency): 27%
Beside the measured number, compound 4's estimate is 3 percentage points above it; the measured number falls inside the stated range.
By their numbers in this assay, from the lowest: compounds 1, 4, 3 and 2 (each within the scatter of the next, the first and the last beyond it).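

With the fluoro removed outright, hydrogen in place of fluoro on an aromatic carbon gives in this assay a number 5 percentage points lower from compound 3 to compound 4 (within the scatter) and a number 9 percentage points lower from compound 2 to compound 4 (within the scatter), so at this one dose neither fluorinated ring can be told apart from the plain phenyl. Among the compounds shown here, the phenyl ring also allows the first single-place comparison at the other substituent: a group of 3 heavy atoms in place of a group of 2 heavy atoms on an aromatic carbon gives a number 4 percentage points higher from compound 1 to compound 4 (within the scatter), so this exchange also stays within the scatter. Nothing offered here gives a reason for any of these steps.

Still open, going by these compounds, is whether a chloro, methoxy or trifluoromethyl group on this ring, or a carboxylic acid or nitrile in place of the group on the aromatic carbon, would give a step beyond the scatter. The read-out comes from a single dose. The potency of these compounds also remains open.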